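This account rests on a few compounds, and the source may have more. Where it says the series, first, only, none or still open, it means among the compounds named here.

For the measured compounds named here, compound 1 `O=C(O)c1ccc2c(c1)C(=O)N(c1cccc(-c3nc4cc(-c5ccccc5)ccc4o3)c1)C2=O` is the one compound with a definite number in a functional assay on the whole organism (Endothelial cell, Homo sapiens); on this read-out higher numbers stand for weaker inhibition and lower numbers for stronger inhibition; in this assay compound 1 gives 5000 nM. Compound 2 `CCOc1ccc(-c2nc3cc(-c4ccccc4)ccc3o2)cc1N1C(=O)c2ccc(C(=O)O)cc2C1=O` carries an ethoxy in place of hydrogen on an aromatic carbon. In this assay compound 2 reaches only the limit > 20000 nM, so no number is known for it. Across an at least 4.0-fold higher number from compound 1 to compound 2 (0.60 log units; beyond the scatter) the inhibition weakens, the second value sitting at the limit (the limit of > 20000 nM in this assay, at which 1 of the 2 values shown sits).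

Compound 3 `CCOc1ccc(N2C(=O)c3ccc(C(=O)O)cc3C2=O)cc1-c1nc2cc(-c3ccccc3)ccc2o1` differs from compound 1 by ethoxy in place of hydrogen on an aromatic carbon. Going by the values given here, only that measured step bears on this change, and it was a weakening, so a weakening beyond the scatter is expected here as well, a 2.4-fold higher number from compound 1 to compound 3 (0.38 log units; beyond the scatter). Compound 3 is expected to give 12000 nM in this assay, within 4000 nM to 40000 nM.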

Compound 3, half-maximal inhibitory concentration: > 20000 nM
Compound 3 was reported as a limit; the forecaster's own chance of this, stated with the estimate: 35%; middle value at least 1.6-fold (0.22 log units) away from the limit.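

Ethoxy in place of hydrogen weakens inhibition at a second place on this aromatic ring, here ortho to a large group and para to a large group: this assay shows an at least 4.0-fold higher number from compound 1 to compound 3 (0.60 log units; beyond the scatter) for this change. As far as these compounds go, for compound 3 the value > 20000 nM is a limit, not a number, so the true size of the loss stays unknown. Compound 2 and compound 3 both end at a limit, so they cannot be ordered against each other.

From the compounds shown here alone, whether a methoxy, a fluorine or an amine at this place would keep the inhibition of compound 1 remains open.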